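The source may report more compounds than this note shows. Statements on the series, on what has been measured and on what is new or still open speak of the compounds shown alone.

Among the compounds with values here, in an ADME assay on microsomes from liver (Homo sapiens) for metabolic stability, read by LC-MS, with a stated time of 10 min, tested at 0.5 uM (on this read-out higher numbers stand for a more stable compound and lower numbers for a less stable compound), compound 2 `c1ccc2c(c1)CN[C@@H](CN(CC[C@@H]1CCCNC1)[C@H]1CCCc3cccnc31)C2` gives 75%, the lowest number of the three measured so far. Compound 1 `c1ccc2c(c1)CN[C@H](CN(CCCN1CCNCC1)[C@H]1CCCc3cccnc31)C2` gives 99%. Compound 3 `c1cnc2c(c1)CN[C@H](CN(CCCN1CCNCC1)[C@H]1CCCc3cccnc31)C2` gives 100%. Both lie beyond the scatter from compound 2 and within the scatter of each other.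

Compound 4 `c1ccc2c(c1)CN[C@@H](CN(CCCN1CCN(C3CC3)CC1)[C@H]1CCCc3cccnc31)C2` differs from compound 2 by (4-cyclopropylpiperazin-1-yl)methyl in place of piperidin-3-yl on a saturated chain carbon, two bonds along the chain from an amine nitrogen. Within the data shown here, the only measured step, a number 1 percentage points higher from compound 1 to compound 3 (within the scatter), concerns a different place in the molecule and gives no direct measure of this change. Among the measured compounds shown here, compound 1 and compound 3 do carry the same kind of non-aromatic ring on the chain as compound 4 does, but neither has the three-membered ring of carbon only, and no pair isolates that ring's contribution. The expectation therefore leans on compound 1 at 99% and compound 3 at 100%, with a discount for the untested cyclopropyl. An estimated a number 13 percentage points higher from compound 2 to compound 4 (beyond the scatter) is expected in this assay. For compound 4 the expected value is 88%, with an estimated range of 70% to 100%.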

Compound 4, percent of the compound remaining: 21%
The estimate for compound 4 lay 67 percentage points above the measured number; measured number below the stated range.
By their numbers in this assay, from the lowest: compound 4; then compound 2; then compounds 1 and 3 (each within the scatter of the next).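

In this assay, the change at this place on the chain, (4-cyclopropylpiperazin-1-yl)methyl in place of piperidin-3-yl, gives a number 54 percentage points lower from compound 2 to compound 4 (beyond the scatter), so the read-out responds strongly to the group carried here. Within the data shown here, this is the first measured step at this place, and the first step to lie beyond the scatter. No measurement is at hand that accounts for the drop.

The entering group differs from the leaving one in several ways at once, including its three-membered ring of carbon only, its piperazine ring, its extra methylene and the loss of the hydrogen-bond donor, and this single step cannot tell these apart. Open, from the compounds shown here alone, is how the read-out would respond to a methyl or an acetyl in place of the cyclopropyl on the piperazine, with the rest of compound 4 unchanged.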